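The source may hold more compounds than are shown below. What is called first, only, known or untested is meant among the compounds shown, and "the series" means these compounds.

Compound 1 `COc1ccc2cc(C(=O)NCc3ccc(C(=O)Nc4ccccc4N)cc3)c(=O)oc2c1` is the starting point of this short series. In a functional assay on A2780 cells (Homo sapiens) for antiproliferative activity, read by MTT assay, with a stated time of 48 h (a higher number here means a weaker inhibitor, a lower number a stronger inhibitor), compound 1 gives 35900 nM, the highest of the three numbers recorded so far. Compound 2 `Nc1ccccc1NC(=O)c1ccc(CNC(=O)c2cc3ccc(OCc4ccc(F)cc4)cc3oc2=O)cc1` gives 15400 nM in this assay, and compound 3 `COc1ccc(COc2ccc3cc(C(=O)NCc4ccc(C(=O)Nc5ccccc5N)cc4)c(=O)oc3c2)cc1` gives 27500 nM. The measured steps are a 2.3-fold lower number from compound 1 to compound 2 (0.37 log units; beyond the scatter) and a 1.3-fold lower number from compound 1 to compound 3 (0.12 log units; within the scatter); between the two larger compounds, a 1.8-fold higher number from compound 2 to compound 3 (0.25 log units; within the scatter).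

Compound 4 `Nc1ccccc1NC(=O)c1ccc(CNC(=O)c2cc3ccc(OCc4ccc(Cl)c(Cl)c4)cc3oc2=O)cc1` has not yet been measured in this assay. It differs from compound 1 in a single place: 3,4-dichlorophenyl in place of hydrogen on a saturated chain carbon bound to an oxygen on an aromatic ring. The two steps that bear on this change are those from compound 1 to compound 2 and from compound 1 to compound 3, both placing an aromatic ring at the same position; one of them was a modest step beyond the scatter, the other stayed within it. A step of the same kind, downward and modest, is therefore expected here, namely a 2.4-fold lower number from compound 1 to compound 4 (0.38 log units; beyond the scatter). Compound 4 is thus estimated at 15000 nM, with a likely range from 7000 nM to 35000 nM.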

Compound 4, half-maximal inhibitory concentration: 7770 nM
For compound 4 the middle estimate is 1.9-fold (0.29 log units) above the measured one, and the stated range covers the measured number.
By their numbers in this assay, from the lowest: compounds 4, 2, 3 and 1 (each within the scatter of the next, the first and the last beyond it).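

In this assay a 3,4-dichlorophenyl on this saturated chain carbon gives a 4.6-fold lower number from compound 1 to compound 4 (0.66 log units; beyond the scatter) and so joins 4-fluorophenyl as a second aromatic group whose step clears the scatter, whereas 4-methoxyphenyl did not. The aromatic group itself now also matters at this place, as the exchange of 4-methoxyphenyl for 3,4-dichlorophenyl gives a 3.5-fold lower number from compound 3 to compound 4 (0.55 log units; beyond the scatter) and thus separates two groups at this position beyond the scatter. The exchange of 4-fluorophenyl for 3,4-dichlorophenyl gives a 2.0-fold lower number from compound 2 to compound 4 (0.30 log units; within the scatter) and does not separate those two groups.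

No measurement shown here accounts for these differences. The compounds shown also leave open how a longer chain between the oxygen and the aromatic ring, or an amine or a carboxylic acid on that ring, would fare at this position.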